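The source may hold more compounds than are shown below. What is called first, only, known or untested is meant among the compounds shown, and "the series" means these compounds.

Compound 1 `O=C1/C(=C2/C(=O)N([C@@H]3O[C@H](CO)[C@@H](O)[C@H](O)[C@H]3O)c3ccccc32)Nc2ccccc21` is the only one of the three compounds shown with a single number: in a functional assay on A-427 cells (Homo sapiens) for antiproliferative activity, read by crystal violet staining, with a stated time of 96 h (a lower number here means a stronger inhibitor, a higher number a weaker inhibitor), compound 1 gives 11800 nM. Compound 2 `C[C@@H]1O[C@@H](N2C(=O)/C(=C3\Nc4ccccc4C3=O)c3ccccc32)[C@H](O)[C@H](O)[C@H]1O` sits at the limit of > 25000 nM in this assay, at which 1 of the 3 values shown sits, so in this assay compound 2 is recorded as a limit, > 25000 nM, and not as a measured number. Compound 3 `C[C@@H]1O[C@H](N2C(=O)/C(=C3\Nc4ccccc4\C3=N/O)c3ccccc32)[C@H](O)[C@H](O)[C@H]1O` has no reported result in this assay; for compound 3 the entry reads "not determined" (no result reported). Compound 4 `O=C1/C(=C2/C(=O)N([C@@H]3O[C@H](CO)[C@@H](O)[C@H](O)[C@@H]3O)c3ccccc32)Nc2ccccc21` is the compound not yet measured, and its relation to compound 1 is the two compounds have the same atoms and bonds and differ only in configuration as drawn: 1 of 6 stereo elements differ; a stereocentre at a saturated ring carbon is drawn R in compound 1 and S in compound 4. Within the data shown here, no step between two measured compounds is available here, so the size of such a change cannot be read from anything measured in this assay. Compound 4 keeps every atom and bond of compound 1, and a change limited to the drawn configuration at one saturated ring carbon is expected to move the result little, in either direction, most likely no further than the ordinary scatter of this assay. The expected step is a 1.1-fold higher number from compound 1 to compound 4 (0.04 log units; within the scatter). Compound 4 is therefore estimated at 13000 nM, with a range from 5000 nM to 30000 nM, and with a real chance that this assay returns only a limit for it.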

Compound 4, half-maximal inhibitory concentration: 5550 nM
Compound 4: the middle estimate sits 2.3-fold (0.37 log units) above what was measured; low and high end bracket the measured number.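

In this assay, redrawing one saturated ring carbon from R to S gives a 2.1-fold lower number from compound 1 to compound 4 (0.33 log units; beyond the scatter), a modest change but one that lies beyond the scatter. Among these compounds, this is the first measured step, and it shows that the configuration at this single carbon can move the result by itself, since no group enters or leaves and the step can be assigned to that carbon alone: the fact that compounds 1 and 4 differ only in the configuration as drawn. Among the compounds shown here, compound 2 is recorded only as a limit, > 25000 nM, so it adds no second measured step to set beside this one.

The compounds shown leave open whether the other stereocentres respond in the same way or to the same extent, and whether this step would hold in any other cell line or read-out. For the compounds shown here, they also leave open what happens when the hydroxyl group at this carbon is replaced by an amine or a methoxy group, so the single step shows that the drawn configuration matters here but not what the result depends on at this carbon.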